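The source may hold more compounds than are shown below. What is called first, only, known or untested is meant among the compounds shown, and "the series" means these compounds.

Measured so far in an assay on cells for displacement of a labelled ligand from transmembrane domain-containing protein TMIGD3 (Homo sapiens), read by scintillation counting, with a stated time of 120 min; on this read-out lower numbers stand for stronger inhibition and higher numbers for weaker inhibition:
compound 1 `Cc1ccc(C(=O)Nc2nc(-c3ccccc3)cn3cc(-c4ccccc4)nc23)cc1` gives 223 nM
compound 2 `O=C(Nc1nc(-c2ccccc2)cn2cc(-c3ccccc3)nc12)c1ccc(Cl)cc1` gives 156 nM

Among the measured compounds shown here, compound 2 has the lower of these two numbers, but the single step that separates it from compound 1, a 1.4-fold lower number from compound 1 to compound 2 (0.16 log units; within the scatter), lies within the scatter, so the two compounds cannot be told apart on these data. Compound 3 `O=C(Nc1nc(-c2ccccc2)cn2cc(-c3ccccc3)nc12)c1cccs1` has not yet been measured. It differs from compound 2 by thiophen-2-yl in place of 4-chlorophenyl on a carbonyl carbon. For the measured compounds named here, only one measured step touches this part of the molecule, a 1.4-fold lower number from compound 1 to compound 2 (0.16 log units; within the scatter), which swapped one group for another on an aromatic carbon of the ring that leaves here, and it stayed within the scatter. Going by the values given here, no measured pair replaces the whole six-membered ring by a five-membered one, so the record gives no direct guide to the size of that change. Among the compounds with values here, with the one neighbouring step small, the expectation for compound 3 is a number close to that of compound 2, estimated as a 1.6-fold higher number from compound 2 to compound 3 (0.20 log units; within the scatter), but with a wide range. Compound 3 is therefore expected to give 250 nM in this assay, somewhere between 80 nM and 800 nM.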

Compound 3, inhibition constant: 185 nM
Compound 3: middle estimate off by 1.4-fold (0.13 log units), on the high side, within the range that was stated.
By their numbers in this assay, from the lowest: compounds 2, 3 and 1 (each within the scatter of the next).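

In this assay, thiophen-2-yl in place of 4-chlorophenyl on the carbonyl carbon is a 1.2-fold higher number from compound 2 to compound 3 (0.07 log units; within the scatter), and the same ring in place of 4-methylphenyl is a 1.2-fold lower number from compound 1 to compound 3 (0.08 log units; within the scatter). Among the compounds shown here, until now, the only measured change here was a swap of one group on an aromatic carbon of the ring. These steps go further and replace the whole six-membered aromatic ring of carbon with a five-membered aromatic ring with one hetero atom, yet the three compounds still cannot be told apart in this assay. Nothing measured here explains why the numbers stay so close.

All three compounds carry an aromatic ring on this carbonyl carbon, so the compounds shown leave open what a group without such a ring would do there, for example a longer carbon chain, or what a ring bearing an amine or a carboxylic acid would do. The rest of the molecule is also identical in all three, so they cannot show whether any other part of it would change the number by more than the scatter.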